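Swapping hydroxy for methylamino on a small side chain

This account rests on a few compounds, and the source may have more. Where it says the series, first, only, none or still open, it means among the compounds named here.

In a functional assay on A2780 cells (Homo sapiens) for antiproliferative activity, read by MTT assay, with a stated time of 48 h (a lower number here means a stronger inhibitor, a higher number a weaker inhibitor), compound 1 `COc1ccc(C(=O)c2ccc(OC)c3c2C=CC(C)(C)O3)c(NC(=O)CO)c1` gives 420 nM, while compound 2 `COc1ccc(C(=O)c2ccc(OC)c3c2OC(C)(C)C=C3)c(NC(=O)CN)c1` gives 380 nM, so these two values lie within the usual scatter of repeated measurements. Compound 3 `CNCC(=O)Nc1cc(OC)ccc1C(=O)c1ccc(OC)c2c1C=CC(C)(C)O2` keeps the core of compound 1 and carries methylamino in place of hydroxy on a saturated chain carbon bound to a carbonyl carbon. Among the measured compounds shown here, no measured pair isolates this swap, so any forecast is loose. In this assay the expected change is small, a 1.1-fold lower number from compound 1 to compound 3 (0.04 log units; within the scatter), staying within the scatter in either direction. Compound 3 is estimated at 380 nM, with an expected range of 130 nM to 1100 nM.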

Compound 3, half-maximal inhibitory concentration: 1590 nM
The estimate for compound 3 lay 4.2-fold (0.62 log units) below the measured number, and the stated range ends below it.
By their numbers in this assay, from the lowest: compounds 2 and 1 (each within the scatter of the next); then compound 3.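

In this assay, among the compounds shown here, methylamino in place of hydroxy on a saturated chain carbon bound to a carbonyl carbon gives a 3.8-fold higher number from compound 1 to compound 3 (0.58 log units; beyond the scatter) and so shows that this position responds to the swap, which the earlier compounds alone could not reveal. The counted hydrogen-bond donors, hydrogen-bond acceptors and net charge stay the same, so these counts do not separate the two compounds. No measurement at hand explains the step. As far as these compounds go, how methoxy or dimethylamino at this place would compare on the core of compound 1 remains open.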